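Swapping the Branched Chain Back for an Aromatic Ring

The source may report more compounds than this note shows. Statements on the series, on what has been measured and on what is new or still open speak of the compounds shown alone.

Compound 2 `CCC(C)(CC)Cc1cnc(CCc2ccc(-c3ccccc3C(=O)O)cc2)[nH]1` gives the lowest of the two numbers available in an in vitro functional assay on cells for agonist activity at Bombesin receptor subtype-3 (Homo sapiens), read by luminescence and calcium flux (a higher number here means that more compound is needed for the effect, a lower number that less compound is needed), namely 76 nM. Going by the values given here, its nearest neighbour is compound 1 `O=C(O)c1ccccc1-c1ccc(CCc2ncc(Cc3ccc(F)cc3)[nH]2)cc1`, which in this assay gives 1600 nM; the only measured step, a 21-fold lower number from compound 1 to compound 2 (1.32 log units; beyond the scatter), came from replacing 4-fluorophenyl with 1-ethyl-1-methylpropyl on a saturated chain carbon bound to an aromatic carbon.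

Compound 3 `N#Cc1ccccc1Cc1cnc(CCc2ccc(-c3ccccc3C(=O)O)cc2)[nH]1` has not yet been measured. It differs from compound 2 by 2-cyanophenyl in place of 1-ethyl-1-methylpropyl on a saturated chain carbon bound to an aromatic carbon. Among the compounds with values here, this change runs opposite to the one measured step: the branched chain that brought the large gain leaves, and a six-membered aromatic ring of carbon only, now bearing a nitrile rather than a fluoro substituent, enters at the same place. Within the data shown here, no pair shows how a nitrile on that ring compares with the fluoro group, so the step is judged from a 21-fold lower number from compound 1 to compound 2 (1.32 log units; beyond the scatter) alone and carries wide uncertainty. Compound 3 is therefore expected to give a higher number than compound 2, as a step of about an 11-fold higher number from compound 2 to compound 3 (1.02 log units; beyond the scatter). The estimate for compound 3 in this assay is 800 nM, with a range from 200 nM to 3200 nM.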

Compound 3, half-maximal effective concentration: 5480 nM
Estimate against measurement, compound 3: 6.9-fold (0.84 log units) below; measured number outside the range, above it.
By their numbers in this assay, from the lowest: compound 2; then compound 1; then compound 3.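

Compound 3 shows that the gain at this position is not simply lost or kept when an aromatic ring returns. In this assay, the branched 1-ethyl-1-methylpropyl group is strongly preferred over 2-cyanophenyl (a 72-fold higher number from compound 2 to compound 3 (1.86 log units; beyond the scatter)), so both ring-bearing compounds, compound 1 and compound 3, now give higher numbers than compound 2. The two rings are also not interchangeable, since the modest step from 4-fluorophenyl to 2-cyanophenyl (a 3.4-fold higher number from compound 1 to compound 3 (0.53 log units; beyond the scatter)) lies beyond the scatter and shows that the group carried by the ring, or where it sits, affects the number even though neither ring approaches compound 2; no evidence at hand explains any of these differences.

The compounds shown leave open whether the nitrile itself or its place on the ring accounts for the step from compound 1 to compound 3, for 2-cyanophenyl and 4-fluorophenyl differ in both respects, and a 4-cyanophenyl or 2-fluorophenyl group would separate the two. They also leave open whether the advantage of the branched chain extends to a saturated ring such as cyclohexyl or to a smaller branched group such as tert-butyl.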